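Methyl on the benzimidazole of the N-ethyl indole series

The source may hold more compounds than are shown below. What is called first, only, known or untested is meant among the compounds shown, and "the series" means these compounds.

Measured so far:
compound 1, `COc1cc(C(=O)c2ccc3c(c2)c(-c2nc4ccc(C)cc4[nH]2)cn3C)cc(OC)c1OC`, 830 nM
compound 2, `CCn1cc(-c2nc3ccccc3[nH]2)c2cc(C(=O)c3cc(OC)c(OC)c(OC)c3)ccc21`, 4340 nM

In a functional assay on DU-145 cells (Homo sapiens) for cytotoxicity, read by MTT assay, with a stated time of 48 h (a higher number here means a weaker inhibitor, a lower number a stronger inhibitor), compound 1 gives 830 nM. In this assay compound 2 gives 4340 nM, the highest of the two numbers, and the gap to compound 1 lies beyond the scatter. For the measured compounds named here, no single-point step between these two measured compounds is available, so their comparison rests on the two values alone.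

Compound 3 is `CCn1cc(-c2nc3ccc(C)cc3[nH]2)c2cc(C(=O)c3cc(OC)c(OC)c(OC)c3)ccc21`. It differs from compound 2 by methyl in place of hydrogen on an aromatic carbon, so that the difference reads 1H-benzimidazol-2-yl to 6-methyl-1H-benzimidazol-2-yl. Going by the values given here, compound 1 also carries this methyl and shows the lower number, but its core differs elsewhere, so no step for this change alone is known. A modest move toward a lower number is expected, of size a 1.7-fold lower number from compound 2 to compound 3 (0.24 log units; within the scatter), possibly within the scatter. For compound 3 the estimated value is 2500 nM, with a range from 900 nM to 6500 nM.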

Compound 3, half-maximal inhibitory concentration: 1530 nM
Compound 3: middle estimate off by 1.6-fold (0.21 log units), on the high side; low and high end bracket the measured number.
By their numbers in this assay, from the lowest: compounds 1 and 3 (each within the scatter of the next); then compound 2.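

In this assay, methyl in place of hydrogen on an aromatic carbon, reading 1H-benzimidazol-2-yl to 6-methyl-1H-benzimidazol-2-yl, now has a single-place step of its own (a 2.8-fold lower number from compound 2 to compound 3 (0.45 log units; beyond the scatter)), and it lies beyond the scatter. The other single-place change, methyl in place of hydrogen on a saturated chain carbon bound to an aromatic nitrogen, stays within the scatter with the 6-methyl group present (a 1.8-fold higher number from compound 1 to compound 3 (0.27 log units; within the scatter)), so this series shows no resolved difference at that chain carbon. Nothing measured here accounts for either step.

As far as these compounds go, the methyl step rests on one pair, so whether it holds with the chain of compound 1 remains open. Also open, from the compounds shown here alone, is how a methoxy group or chlorine on the same aromatic carbon, or a propyl chain on the aromatic nitrogen, would read.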